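Swapping a Phenol for a Dimethoxyphenyl: What Compound 4 May Show

The source may hold more compounds than are shown below. What is called first, only, known or untested is meant among the compounds shown, and "the series" means these compounds.

Compound 1 `COc1cc(CNC(=O)/C=C/c2ccccc2O)ccc1OCc1nc(C)c(C)nc1C`: 5300 nM
Compound 2 `COc1cc(/C=C/C(=O)NCc2ccc(OCc3nc(C)c(C)nc3C)c(OC)c2)ccc1O`: 13400 nM
Compound 3 `COc1ccc(/C=C/C(=O)NCc2ccc(OCc3nc(C)c(C)nc3C)c(OC)c2)cc1O`: 8560 nM

In a functional assay on SH-SY5Y cells (Homo sapiens) for cytotoxicity, read by MTT assay, with stated times of 24 h and 4 h (on this read-out higher numbers stand for an effect only at larger amounts of compound and lower numbers for an effect already at smaller amounts), compound 3 holds the second highest of the three numbers. Two steps lead to it, a 1.6-fold lower number from compound 2 to compound 3 (0.19 log units; within the scatter) and a 1.6-fold higher number from compound 1 to compound 3 (0.21 log units; within the scatter), both within the scatter, so compound 3 cannot be ordered against either neighbour.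

Compound 4 `COc1cc(/C=C/C(=O)NCc2ccc(OCc3nc(C)c(C)nc3C)c(OC)c2)cc(OC)c1` differs from compound 3 by 3,5-dimethoxyphenyl in place of 3-hydroxy-4-methoxyphenyl on a double-bonded chain carbon bound to a double-bonded chain carbon. The measured steps bearing on this ring are a 2.5-fold higher number from compound 1 to compound 2 (0.40 log units; beyond the scatter), a 1.6-fold higher number from compound 1 to compound 3 (0.21 log units; within the scatter) and a 1.6-fold lower number from compound 2 to compound 3 (0.19 log units; within the scatter); only the first exceeds the scatter, and none of them removes the hydrogen-bond donor, so the new change goes beyond what has been tested. In this assay a step of modest size at most is expected for compound 4, direction uncertain, a 1.1-fold higher number from compound 3 to compound 4 (0.05 log units; within the scatter). Compound 4 is therefore estimated at 9500 nM, with a range from 4000 nM to 22000 nM.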

Compound 4, half-maximal effective concentration: 8660 nM
Beside the measured number, compound 4's estimate is 1.1-fold (0.04 log units) above it, within the range that was stated.
By their numbers in this assay, from the lowest: compounds 1, 3, 4 and 2 (each within the scatter of the next, the first and the last beyond it).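

In this assay, 3,5-dimethoxyphenyl, with 0 hydrogen-bond donors, replaces 3-hydroxy-4-methoxyphenyl with a 1.0-fold higher number from compound 3 to compound 4 (0.01 log units; within the scatter), and the comparisons with the other rings, a 1.5-fold lower number from compound 2 to compound 4 (0.19 log units; within the scatter) and a 1.6-fold higher number from compound 1 to compound 4 (0.21 log units; within the scatter), also stay within the scatter. Among these compounds, then, a hydrogen-bond donor on this ring is not needed for a number at this level. Nothing available explains this result. Still open, going by these compounds, is whether an amine or a carboxylic acid on this ring would move the number beyond the scatter.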